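Removing a chloro group from a compound at the limit

A few compounds are considered here, and "the series" means these few. Any claim that something is new, unique, unknown or untested is made for them only; others in the source may bear on it.

Measured in a functional assay on OVCAR-3 cells (Homo sapiens) for antiproliferative activity, read by spectrophotometry, with a stated time of 2 days; a higher number here means a weaker inhibitor of growth, a lower number a stronger inhibitor of growth:
- Compound 1 `Cc1ccc(Nc2ncc(C(F)(F)F)c(N3Cc4cccc(N(C)S(C)(=O)=O)c4C3)n2)cc1C`: > 30000 nM
- Compound 2 `CN(c1cccc2c1CN(c1nc(Nc3cc(C(F)(F)F)cc(C(F)(F)F)c3)ncc1C(F)(F)F)C2)S(C)(=O)=O`: > 30000 nM
- Compound 3 `CN(c1cccc2c1CN(c1nc(Nc3ccc(Cl)c(C(F)(F)F)c3)ncc1C(F)(F)F)C2)S(C)(=O)=O`: > 50000 nM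

Compound 3 stands at > 50000 nM, which is a limit and not a number. For the measured compounds named here, the other two entries are limits as well, so no compound here has yet given a true value. The results sit at two limits: the limit of > 30000 nM in this assay, at which 2 of the 3 values shown sit, and (the limit of > 50000 nM in this assay, at which 1 of the 3 values shown sits).

Compound 4 `CN(c1cccc2c1CN(c1nc(Nc3cccc(C(F)(F)F)c3)ncc1C(F)(F)F)C2)S(C)(=O)=O` has not yet been measured. It carries hydrogen in place of chloro on an aromatic carbon, ortho to a trifluoromethyl group and para to a large group: hydrogen in place of chloro on an aromatic carbon.

Going by the values given here, only one measured step changes this same aromatic group: a step that the two limits leave unreadable from compound 1 to compound 3. Among the compounds with values here, it gives no size to build on, and no measured step shows the removal of chloro on its own. The expectation therefore rests on the limit of compound 1, > 30000 nM, and the limit of compound 2, > 30000 nM, taken together with that of compound 3. Compound 4 is expected to return only a limit too, with no step in either direction beyond the scatter. The expected change is an at least 1.6-fold lower number from compound 3 to compound 4 (0.22 log units; that floor lies within the scatter). For compound 4 the estimated value is 30000 nM, with an expected range from 8000 nM to 60000 nM.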

Compound 4, concentration for 50% growth inhibition: > 30000 nM
Compound 4: only a limit was reported; the forecaster's own chance of this, stated with the estimate: 85%; the middle value lies on the limit itself.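

Compound 4 gives > 30000 nM in this assay, which is a limit and not a number. Compound 1, compound 2 and compound 3 also stand at limits, and the steps from each of them to compound 4 cannot be read. The compounds shown leave open what true growth-inhibition value any of them has and how much each change on the aromatic group alters it.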